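Sulfonyl aryl variation in the benzimidazole enone series

The compounds below may be only part of what the source reports. "The series", "measured", "known", "first", "only" and "open" are said of these compounds alone.

Compound 3 `Cc1ccccc1S(=O)(=O)Nc1cccc(/C=C/C(=O)c2nc3ccccc3[nH]2)c1` stands second of the three compounds in an assay on isolated protein for inhibition of cathepsin S (Homo sapiens), read by fluorescence, with stated times of 15 min and 30 min, tested at 5 uM (a higher number here means more inhibition at the concentration tested (going by the name of the read-out), a lower number less inhibition), where compound 3 gives 47.8%. Compound 1 `O=C(Nc1cccc(/C=C/C(=O)c2nc3ccccc3[nH]2)c1)c1cccc(Cl)c1` sits below it, with compound 1 giving 19.5%, the gap being a number 28.3 percentage points higher from compound 1 to compound 3 (beyond the scatter). Compound 2 `O=C(/C=C/c1cccc(NS(=O)(=O)c2ccc(Cl)cc2)c1)c1nc2ccccc2[nH]1` sits above, with compound 2 giving 89.4%, and the gap there is a number 41.6 percentage points lower from compound 2 to compound 3 (beyond the scatter).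

Compound 4 `Cc1cccc(S(=O)(=O)Nc2cccc(/C=C/C(=O)c3nc4ccccc4[nH]3)c2)c1` differs from compound 3 in one place: 3-methylphenyl in place of 2-methylphenyl on a sulfonyl sulfur. Among the measured compounds shown here, the only measured step at the sulfonyl sulfur is a number 41.6 percentage points lower from compound 2 to compound 3 (beyond the scatter), which shows the aryl on that sulfur can move the read-out by a large amount, but it changes both the substituent and its position at once, so it does not fix the direction for a methyl shift alone. The move from compound 3 to compound 4 concerns only the aryl on the sulfonyl sulfur. The steps of a number 69.9 percentage points higher from compound 1 to compound 2 (beyond the scatter) and a number 28.3 percentage points higher from compound 1 to compound 3 (beyond the scatter) concern a different part of the molecule and do not bear on it.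

For the measured compounds named here, with no step that isolates the methyl position, the step of a number 7.2 percentage points higher from compound 3 to compound 4 (within the scatter) is expected to be small, possibly within the scatter, with an upward lean given that compound 2 gives 89.4% with a different aryl on the same sulfur. Compound 4 is therefore estimated at 55%, with a range from 30% to 82%.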

Compound 4, a percentage reported as inhibition, at one concentration (the size of the read-out at that concentration, not a potency): 50.1%
The estimate for compound 4 lay 4.9 percentage points above the measured number; measured number inside the range.
By their numbers in this assay, from the lowest: compound 1; then compounds 3 and 4 (each within the scatter of the next); then compound 2.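

In this assay, 3-methylphenyl in place of 2-methylphenyl on a sulfonyl sulfur gives a number 2.3 percentage points higher from compound 3 to compound 4 (within the scatter), so moving the methyl between these two named positions does not separate the two compounds. The other two steps are both beyond the scatter: 3-methylphenyl in place of 4-chlorophenyl gives a number 39.3 percentage points lower from compound 2 to compound 4 (beyond the scatter), and (3-methylphenyl)sulfonyl in place of (3-chlorophenyl)carbonyl gives a number 30.6 percentage points higher from compound 1 to compound 4 (beyond the scatter), so compound 4 stays apart from both compound 1 and compound 2. Nothing measured here accounts for these numbers.

Still open, as far as these compounds go, is whether the gap to compound 2 follows the chlorine or its place on the ring, a question that 4-methylphenyl and 3-chlorophenyl on the sulfonyl sulfur would address. From the compounds shown here alone, how an amine or a carboxylic acid on that aryl would read in this assay also remains open.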